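Exchange of a para substituent in an aryl pyridazinone series

The source may hold more compounds than are shown below. What is called first, only, known or untested is meant among the compounds shown, and "the series" means these compounds.

The study concerns a small set of compounds sharing one core. Compound 1, `Cc1cc(C2=NN(c3ccc(S(C)(=O)=O)cc3)C(=O)CC2)ccc1O`, and compound 2, `CCc1ccc(C2=NN(c3ccc(S(C)(=O)=O)cc3)C(=O)CC2)cc1`, were both tested in a functional assay on the whole organism (strain Wistar) for inhibition, with Rattus norvegicus as the target, read by paw edema, with stated times of 30 min and 5 h, at a dose of 0.05 mmol/kg by the oral route; on this read-out higher numbers stand for more inhibition at the one dose given (going by the name of the read-out) and lower numbers for less inhibition; in this assay compound 1 gives 60.5% and compound 2 gives 65.7%. Among the measured compounds shown here, the only comparison available, a number 5.2 percentage points higher from compound 1 to compound 2 (within the scatter), lies within the scatter, so the two compounds cannot be placed in an order on these numbers. Compound 2 thus shows the higher of the two numbers without standing apart from compound 1.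

The next compound, compound 3, `CS(=O)(=O)c1ccc(N2N=C(c3ccc(Oc4ccccc4)cc3)CCC2=O)cc1`, is not yet measured. It differs from compound 2 by phenoxy in place of ethyl on an aromatic carbon. For the measured compounds named here, no measured step exchanges ethyl for phenoxy, so nothing bears on this change directly; the one step recorded, from a 4-hydroxy-3-methylphenyl to a 4-ethylphenyl group, was small. On that basis a change of similar size, in no set direction and not beyond the scatter, is expected, namely a number 5.7 percentage points lower from compound 2 to compound 3 (within the scatter). Compound 3 is therefore estimated to reach 60% in this assay, within a range from 40% to 80%.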

Compound 3, a percentage reported as inhibition, in the whole organism at one dose (the size of the read-out at that dose, not a potency): 65.7%
For compound 3 the middle estimate is 5.7 percentage points below the measured one; measured number inside the range.
By their numbers in this assay, from the lowest: compounds 1, 2 and 3 (each within the scatter of the next).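

In this assay, phenoxy in place of ethyl on an aromatic carbon gives no change at the digits printed from compound 2 to compound 3 (within the scatter). The earlier compounds shown here carried no ring at this place, so this step adds what they could not show: a phenoxy group, with its six-membered aromatic ring and its oxygen, can stand on this aromatic carbon, para to a large group, with the read-out staying within the scatter of the ethyl compound at the one dose given. Nothing available accounts for this result or shows how the phenoxy group acts at this position.

As far as these compounds go, whether an amine, a carboxylic acid or a longer chain such as hexyl would also leave the read-out within the scatter at this place remains open, as does the effect of a substituent on the outer ring of the phenoxy group. From the compounds shown here alone, since the read-out gives the size of the effect at one dose and not a potency, it also remains open whether ethyl and phenoxy would stay this close at other doses.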